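From ethoxy to amino on a carbonyl carbon

This account rests on a few compounds, and the source may have more. Where it says the series, first, only, none or still open, it means among the compounds named here.

Compound 1 (`CCOC(=O)/C=C/c1ccncc1-c1ccc2[nH]ccc2c1`): > 10000 nM
Compound 2 (`CCOC(=O)/C=C/c1ccncc1-c1ccc2ccccc2c1`): 8090 nM

Both compounds were tested in a functional assay on MDA-MB-231 cells (Homo sapiens) for inhibition, read by sulforhodamine B assay, with a stated time of 72 h (on this read-out higher numbers stand for weaker inhibition of growth and lower numbers for stronger inhibition of growth), and only one of them gave a number. The entry for compound 1 of > 10000 nM is a limit of the assay and not a number. Compound 2 at 8090 nM therefore holds the only actual figure so far, and it stands alone as a reference point.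

The next compound, compound 3 (`NC(=O)/C=C/c1ccncc1-c1ccc2ccccc2c1`), has yet to be measured. Compared with compound 2, it carries amino in place of ethoxy on a carbonyl carbon and so turns ethoxycarbonyl into carbamoyl. Within the data shown here, no measured pair shows what this exchange does in this assay and the expectation rests on compound 2 at 8090 nM alone. No clear shift in either direction is expected, only a change within the usual scatter. The expected change is a 1.1-fold higher number from compound 2 to compound 3 (0.05 log units; within the scatter) in this estimate. A reading at the limit of the assay would not be surprising. For compound 3 the estimated value is 9000 nM with an expected range from 3000 nM to 25000 nM in this assay.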

Compound 3, concentration for 50% growth inhibition: > 10000 nM
Compound 3: a limit, no number; the forecaster's own chance of this, stated with the estimate: 40%; at least 1.1-fold (0.04 log units) between middle value and limit.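

Where the earlier compounds offered no pair differing in one place, this result gives one: amino in place of ethoxy on a carbonyl carbon, which turns ethoxycarbonyl into carbamoyl, yields an at least 1.2-fold higher number from compound 2 to compound 3 (0.09 log units; that floor lies within the scatter) in this assay. Compound 3 gives > 10000 nM, which is a limit of the assay and not a number. The exchange thus shows no stronger inhibition of growth with carbamoyl than with ethoxycarbonyl, while the size of the step stays open because the reading for compound 3 is a limit: the limit of > 10000 nM in this assay, at which 2 of the 3 values shown sit.

The compounds shown leave open whether any other group on this carbonyl carbon, such as methylamino, dimethylamino or the hydroxyl of a carboxylic acid, would give a number on either side of that of compound 2. They also leave open whether the same exchange would read alike on the core of compound 1, or whether a saturated ethyl chain in place of the double-bonded one would alter the picture.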